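Urea versus amide on a shared core: a limit-bound step

The compounds below may be only part of what the source reports. "The series", "measured", "known", "first", "only" and "open" are said of these compounds alone.

Compound 1 `COc1cc(-c2nn(-c3cccc(NC(=O)Nc4cc(C(F)(F)F)cc(C(F)(F)F)c4)c3)cc2-c2ccncc2)ccc1Cl` carries a bis(trifluoromethyl)phenyl urea and in a functional assay on OVCAR-5 cells (Homo sapiens) for inhibition, read by sulforhodamine B assay, with a stated time of 48 h (a lower number here means a stronger inhibitor of growth, a higher number a weaker inhibitor of growth), compound 1 gives 2470 nM. Compound 2 `COc1cc(-c2nn(-c3cccc(NC(=O)c4cccc(C(F)(F)F)c4)c3)cc2-c2ccncc2)ccc1Cl` replaces the urea by a benzamide, and in this assay compound 2 reaches only the limit > 50000 nM. Compound 3 `COc1cc(-c2nn(-c3cccc(NC(=O)Nc4ccc(Cl)c(Cl)c4)c3)cc2-c2ccncc2)ccc1Cl` is again a urea, now bearing a dichlorophenyl group, and in this assay compound 3 also sits at the limit > 50000 nM. The step that the two limits leave unreadable from compound 2 to compound 3 therefore cannot be read, and compound 3 stands only as a limit among the numbers shown; of the three values, two rest at that limit (the limit of > 50000 nM in this assay, at which 2 of the 3 values shown sit). Compound 4 `COc1cc(-c2nn(-c3cccc(NC(=O)Nc4cccc(C(F)(F)F)c4)c3)cc2-c2ccncc2)ccc1Cl` differs from compound 3 by 3-(trifluoromethyl)phenyl in place of 3,4-dichlorophenyl on an amide-type nitrogen. For the measured compounds named here, no measured step bears directly on this change: the only step available is the unreadable one from compound 2 to compound 3. The nearest anchor is compound 1, which carries two trifluoromethyl groups on the same urea and gives 2470 nM. Compound 3 with its dichlorophenyl urea reaches only the limit of this assay. Compound 4 is therefore expected to fall between these, with the step of an at least 3.3-fold lower number from compound 3 to compound 4 (0.52 log units; beyond the scatter) estimated as a gain that may or may not clear the limit. The expected value for compound 4 is 15000 nM, within the range 3000 nM to 50000 nM.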

Compound 4, concentration for total growth inhibition: 6450 nM
The estimate for compound 4 lay 2.3-fold (0.37 log units) above the measured number; the measured number falls inside the stated range.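

In this assay, this position now yields readable steps: (3-(trifluoromethyl)phenyl)amino in place of 3-(trifluoromethyl)phenyl on a carbonyl carbon, which turns the benzamide into a urea, brings an at least 7.7-fold lower number from compound 2 to compound 4 (0.88 log units; beyond the scatter), and 3-(trifluoromethyl)phenyl in place of 3,4-dichlorophenyl on an amide-type nitrogen brings an at least 7.7-fold lower number from compound 3 to compound 4 (0.88 log units; beyond the scatter). So neither the urea alone nor the amide-type link with this aryl group accounts for the activity; among these compounds it appears only when the urea carries a trifluoromethyl-bearing phenyl, and the second trifluoromethyl group adds little, with hydrogen in its place on an aromatic carbon giving a 2.6-fold higher number from compound 1 to compound 4 (0.42 log units; beyond the scatter). The two larger steps are lower bounds and not measured sizes: the limit of > 50000 nM in this assay, at which 2 of the 4 values shown sit.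

The compounds shown leave open whether a nitrile, a methoxy group or a single chlorine could stand in for trifluoromethyl on the phenyl of the urea. They also leave open what a methyl group in place of the amide hydrogen would do to the number in this assay.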